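Working notes: morpholin-4-yl to benzylamino on the carbonyl

A few compounds are considered here, and "the series" means these few. Any claim that something is new, unique, unknown or untested is made for them only; others in the source may bear on it.

Measured so far in a physicochemical assay for lipophilicity, read by HPLC; on this read-out lower numbers stand for lower lipophilicity and higher numbers for higher lipophilicity:
- Compound 1 `Cc1ccsc1C(=CCCN(C)C(CCO)C(=O)N1CCOCC1)c1sccc1C`: 4.75
- Compound 2 `Cc1ccsc1C(=CCCN(C)C(CCN)C(=O)NCc1ccccc1Cl)c1sccc1C`: 6.11

In this assay, compound 1 stands lowest of the two measured compounds at 4.75, and compound 2 reads 6.11. The gap between the two lies beyond the scatter. Compound 3 `Cc1ccsc1C(=CCCN(C)C(CCO)C(=O)NCc1ccccc1)c1sccc1C` has not yet been measured. It differs from compound 1 in one place: benzylamino in place of morpholin-4-yl on a carbonyl carbon. In short, benzylamino stands in place of morpholin-4-yl on a carbonyl carbon. For the measured compounds named here, no measured step isolates this change, so the expectation is tentative. Going by the values given here, compound 2, at 6.11, gives the only reading available above the starting point and serves as a loose upper guide. An upward move beyond the scatter is expected, and the estimated size is a number 0.85 log units higher from compound 1 to compound 3 (beyond the scatter). For compound 3 the estimated value is 5.6. The expected range for compound 3 runs from 5.1 to 6.1.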

Compound 3, partition coefficient: 5.71
Beside the measured number, compound 3's estimate is 0.11 log units below it; the range from low to high includes it.
By their numbers in this assay, from the lowest: compound 1; then compound 3; then compound 2.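

In this assay, for the compounds shown here, the replacement of morpholin-4-yl by benzylamino on a carbonyl carbon gives the first single-place step, a number 0.96 log units higher from compound 1 to compound 3 (beyond the scatter). The group on this carbonyl carbon can therefore shift the read-out beyond the scatter while the rest of compound 1 stays unchanged. Nothing available gives a measured reason for this step.

The change swaps a six-membered non-aromatic ring for a six-membered aromatic ring of carbon only and also adds a hydrogen-bond donor, so the compounds shown do not separate these two differences. Cyclohexylmethylamino or benzyl(methyl)amino on the same carbonyl carbon would pull them apart, while a longer chain such as phenethylamino would test the link to the aromatic ring.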